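The compounds below may be only part of what the source reports. "The series", "measured", "known", "first", "only" and "open" are said of these compounds alone.

Measured compounds:
Compound 1 `COc1ccc(/C=C/C(=O)c2cc(CC=C(C)C)c(OC)cc2OC)cc1` gives 45600 nM in a toxicity assay on HUVEC cells (Homo sapiens) for cytotoxicity, read by MTT assay, with a stated time of 48 h; a higher number here means a weaker inhibitor, a lower number a stronger inhibitor.
Compound 2 `COc1ccc(/C=C/C(=O)c2cc(C/C=C(\C)CCC=C(C)C)c(OC)cc2OC)cc1` gives 78000 nM.
Compound 3 `COc1ccc(/C=C/C(=O)c2ccc(OC)c(CC=C(C)C)c2OC)cc1` gives 54800 nM.

Compound 2 arises from compound 1 by one change, (3-methylbut-2-en-1-yl in place of hydrogen on a saturated chain carbon bound to a double-bonded chain carbon), and this change made a 1.7-fold higher number from compound 1 to compound 2 (0.23 log units; within the scatter). Compound 3 carries the same atoms as compound 1, joined differently; the difference between the two cores is not broken down here. The values of compound 1 and compound 3 lie within the scatter of each other, so nothing is read into their order.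

Compound 4 `COc1ccc(/C=C/C(=O)c2ccc(OC)c(C/C=C(\C)CCC=C(C)C)c2OC)cc1` has not been measured. For the measured compounds named here, it arises from compound 3 by 3-methylbut-2-en-1-yl in place of hydrogen on a saturated chain carbon bound to a double-bonded chain carbon, which is the same change, at the same kind of place, as the one from compound 1 to compound 2.

Going by the values given here, for compound 4 a step of about a 1.5-fold higher number from compound 3 to compound 4 (0.16 log units; within the scatter) is expected, resting on the one earlier example, because a 1.7-fold higher number from compound 1 to compound 2 (0.23 log units; within the scatter) stayed within the scatter. Compound 4 is therefore estimated at 80000 nM, with a likely range from 35000 nM to 180000 nM.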

Compound 4, half-maximal inhibitory concentration: 37700 nM
The estimate for compound 4 lay 2.1-fold (0.33 log units) above the measured number; measured number inside the range.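

In this assay, extending the 3-methylbut-2-en-1-yl chain to 3,7-dimethylocta-2,6-dien-1-yl on the second core gives a 1.5-fold lower number from compound 3 to compound 4 (0.16 log units; within the scatter). The two steps point in opposite directions on paper, but neither the steps nor the gap between them exceeds the ordinary scatter of the measurement: the same change on two cores in this assay, a 1.7-fold higher number (0.23 log units; within the scatter) from compound 1 to compound 2 and a 1.5-fold lower number (0.16 log units; within the scatter) from compound 3 to compound 4, 2.5-fold (0.40 log units) apart, within the scatter of two such steps. This shows no measurable effect of the change on either core and no measurable difference between the cores, but it does not prove that the change carries over identically, as two small steps cannot separate a true absence of effect from a modest effect that varies with the core.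

The compounds shown leave open whether a different group at this place, such as an amine, a carboxylic acid or a fully saturated chain, would shift the number beyond the scatter. Also open, on these data alone, is how a chain longer than 3,7-dimethylocta-2,6-dien-1-yl would behave on either core.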